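The compounds below may be only part of what the source reports. "The series", "measured", "known", "first", "only" and "open" are said of these compounds alone.

Among the measured compounds shown here, compound 2 `Cc1c(C2CC2)nc2ccc(-n3ccc(OCc4ccccn4)cc3=O)cn12` has the higher of the two numbers measured so far in an assay on CHO cells for displacement of a labelled ligand from melanin-concentrating hormone receptor 1 (Rattus norvegicus), read by scintillation counting, with a stated time of 1 h (on this read-out higher numbers stand for weaker inhibition and lower numbers for stronger inhibition), where compound 2 gives 150 nM. Its nearest neighbour is compound 1 `Cc1c(C2CC2)nc2ccc(-n3ccc(OCc4ccc(C(F)(F)F)cc4)cc3=O)cn12`, which in this assay gives 82 nM; the step of a 1.8-fold higher number from compound 1 to compound 2 (0.26 log units; within the scatter) lies within the scatter, so the two cannot be told apart. Compound 3 `Cc1c(C2CC2)nc2ccc(-n3ccc(OCc4cccnc4)cc3=O)cn12` differs from compound 2 only in the change pyridin-3-yl in place of pyridin-2-yl on a saturated chain carbon bound to an oxygen on an aromatic ring: the same atoms are present, joined differently. For the measured compounds named here, no measured step moves the nitrogen within this ring, and the one step known, from compound 1 to compound 2, shows that exchanging the whole group at this place left the number essentially unchanged. On that basis no shift beyond the scatter is expected, and the estimated step is no change at the digits printed from compound 2 to compound 3 (within the scatter). Compound 3 is therefore expected to give about 150 nM in this assay, with a range from 60 nM to 400 nM.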

Compound 3, half-maximal inhibitory concentration: > 1000 nM
Compound 3 ended at the assay's limit (the forecaster's own chance of this, stated with the estimate: 3%); at least 6.6-fold (0.82 log units) between middle value and limit.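

Compound 3 gives > 1000 nM in this assay, which is a limit of the assay and not a number: the limit of > 1000 nM in this assay, at which 1 of the 3 values shown sits. Even so, the limit is enough to show a real loss when only the ring nitrogen's place changes, with an at least 6.6-fold higher number from compound 2 to compound 3 (0.82 log units; beyond the scatter), and exchanging the whole group gives an at least 12-fold higher number from compound 1 to compound 3 (1.08 log units; beyond the scatter). The earlier step, a 1.8-fold higher number from compound 1 to compound 2 (0.26 log units; within the scatter), lay within the scatter and suggested a tolerant position, whereas this result shows that the position, on a saturated chain carbon bound to an oxygen on an aromatic ring, distinguishes pyridin-2-yl from pyridin-3-yl despite their identical atoms.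

On these data alone, how far compound 3 lies past its limit remains open. The data do not explain the loss. Also open, as far as these compounds go, is where pyridin-4-yl or an unsubstituted phenyl group at this place would fall.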